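This account rests on a few compounds, and the source may have more. Where it says the series, first, only, none or still open, it means among the compounds named here.

Measured in a functional assay on SW-620 cells (Homo sapiens) for antiproliferative activity, read by MTT assay, with a stated time of 24 h; on this read-out higher numbers stand for weaker inhibition and lower numbers for stronger inhibition:
- compound 1 `COc1ccc(/C=C/C(=O)c2ccc(OC)c3c2OC(C)(C)C=C3)c(F)c1` gives 6570 nM
- compound 2 `COc1ccc(C(=O)/C=C/c2cccc([N+](=O)[O-])c2)c2c1C=CC(C)(C)O2` gives 4090 nM
- compound 3 `COc1ccc(C(=O)/C=C/c2ccc(Cl)cc2)c2c1C=CC(C)(C)O2` gives > 10000 nM (a limit, not a number)

Compound 3 stands at the limit of > 10000 nM in this assay, at which 1 of the 3 values shown sits. Compound 4 `COc1ccc(C(=O)/C=C/c2ccc(Cl)c(Cl)c2)c2c1C=CC(C)(C)O2` differs from it by chloro in place of hydrogen on an aromatic carbon, ortho to a chloro group, turning 4-chlorophenyl into 3,4-dichlorophenyl (chloro in place of hydrogen on an aromatic carbon).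

The measured steps all exchange this same aryl group, though none adds a chloro: a 1.6-fold lower number from compound 1 to compound 2 (0.21 log units; within the scatter), an at least 1.5-fold higher number from compound 1 to compound 3 (0.18 log units; that floor lies within the scatter) and an at least 2.4-fold higher number from compound 2 to compound 3 (0.38 log units; beyond the scatter). All are small or modest, so only a small change is expected, with no firm direction. The expected step is an at least 1.1-fold lower number from compound 3 to compound 4 (0.04 log units; that floor lies within the scatter). The estimate for compound 4 is 9000 nM, with an expected range of 3500 nM to 20000 nM.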

Compound 4, half-maximal inhibitory concentration: 7700 nM
For compound 4 the middle estimate is 1.2-fold (0.07 log units) above the measured one; the range from low to high includes it.
By their numbers in this assay, from the lowest: compounds 2, 1 and 4 (each within the scatter of the next). At a limit, above all of these: compound 3.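

Chloro in place of hydrogen, ortho to a chloro group, turns 4-chlorophenyl into 3,4-dichlorophenyl and gives a measured number in this assay where compound 3 has only a limit, so the step is only a floor, an at least 1.2-fold lower number from compound 3 to compound 4 (0.11 log units; that floor lies within the scatter): the limit of > 10000 nM in this assay, at which 1 of the 4 values shown sits.
Against the other aryl groups the readings are a 1.9-fold higher number from compound 2 to compound 4 (0.27 log units; within the scatter) and a 1.2-fold higher number from compound 1 to compound 4 (0.07 log units; within the scatter) and neither separates compound 4 from them.

Going by these compounds, the true size of the chloro step stays open while compound 3 rests on a limit. Also open, on these data alone, is how an amine or a carboxylic acid on this aromatic carbon would read.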